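Trading a Morpholine Amide for a Methyl Amide

This account rests on a few compounds, and the source may have more. Where it says the series, first, only, none or still open, it means among the compounds named here.

Of the compounds shown here, three have been measured in an assay on a protein complex for inhibition of CDK8/Cyclin C (Homo sapiens), with a stated time of 1 h; a higher number here means a weaker inhibitor, a lower number a stronger inhibitor. Compound 1 `CNC(=O)/C=C/c1ccncc1-c1ccc2ccccc2c1` gives 12.4 nM. Compound 2 `O=C(/C=C/c1ccncc1-c1ccc2[nH]ccc2c1)N1CCOCC1` gives 190 nM, and compound 3 `Cn1ccc2cc(-c3cnccc3/C=C/C(=O)N3CCOCC3)ccc21` gives 247 nM. Compound 2 stands second highest of the three numbers: its nearest neighbour is compound 3, reached by a 1.3-fold higher number from compound 2 to compound 3 (0.11 log units; within the scatter), a step that stays within the scatter, while compound 1 sits far lower, beyond the scatter.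

The unmeasured compound 4 `CNC(=O)/C=C/c1ccncc1-c1ccc2[nH]ccc2c1` differs from compound 2 by methylamino in place of morpholin-4-yl on a carbonyl carbon. Within the data shown here, no measured step covers this change directly. Among the measured compounds shown here, the single measured step, from compound 2 to compound 3, alters the aromatic nitrogen instead and was within the scatter, so it says nothing about the amide end. Compound 1 carries the same methylamino on its carbonyl but a different aromatic partner, so compound 1 and compound 2 differ in two places at once; what their values show is that compound 1 at 12.4 nM lies well below compound 2 at 190 nM, a gap that may belong partly or wholly to either change.

Compound 4 is therefore expected to give 45 nM, within a range from 12 nM to 170 nM. That expectation amounts to a step of a 4.2-fold lower number from compound 2 to compound 4 (0.63 log units; beyond the scatter).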

Compound 4, half-maximal inhibitory concentration: 51.9 nM
Compound 4: middle estimate off by 1.2-fold (0.06 log units), on the low side; the range from low to high includes it.
By their numbers in this assay, from the lowest: compound 1; then compound 4; then compounds 2 and 3 (each within the scatter of the next).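

Among these compounds, the step of a 3.7-fold lower number from compound 2 to compound 4 (0.56 log units; beyond the scatter) in this assay is the first measured change at the amide end, and it shows that replacing morpholin-4-yl with methylamino on the carbonyl carbon matters on its own, with the rest of the molecule held fixed; the earlier step, which altered only the aromatic nitrogen, stayed within the scatter. The amide change does not close the whole distance to compound 1, however: compound 4 gives 51.9 nM, while compound 1, which has the same methylamino on a different aromatic partner, gives 12.4 nM, so the aromatic partner also makes a difference. No available evidence explains why the amide swap gives a lower number.

The compounds shown leave open which part of the swap carries the step, since it removes the ring and its oxygen and brings in the amide hydrogen all at once. A dimethylamino group, which has no amide hydrogen, and a piperidin-1-yl ring, which keeps the ring but has no oxygen, would help to separate these features.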